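This account rests on a few compounds, and the source may have more. Where it says the series, first, only, none or still open, it means among the compounds named here.

Of the compounds shown here, two sharing one core have been tested so far. Compound 1 `COc1cc(O)c(C(=O)/C=C/c2ccc(F)cc2)c(OC)c1` was recorded in a functional assay on MDA-MB-231 cells (Homo sapiens), read by fluorescence and BrdU incorporation, with a stated time of 48 h, tested at 25 uM (on this read-out higher numbers stand for a weaker effect at the one concentration tested and lower numbers for a stronger effect), as "not active" (no number reported), with no number attached. Compound 2 `COc1cc(OC)c(C(=O)/C=C/c2ccccc2SC)c(OC)c1` holds the only number shown: in this assay compound 2 gives 16%, a low figure that stands for a strong effect at the one concentration tested. Compound 3 `COc1cccc(/C=C/C(=O)c2c(OC)cc(OC)cc2OC)c1` keeps the core of compound 2 and changes only the ring at the far end of the chain: 3-methoxyphenyl in place of 2-(methylsulfanyl)phenyl on a double-bonded chain carbon bound to a double-bonded chain carbon. Going by the values given here, no measured pair shows how such a swap moves this read-out, so its direction and size are open. Resting on the single number for compound 2, the step is expected to be a number 24 percentage points higher from compound 2 to compound 3 (beyond the scatter), a move toward a weaker effect somewhat beyond the usual scatter, though a figure close to compound 2 cannot be excluded. Compound 3 is therefore expected to give 40%, within 10% to 85%.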

Compound 3, a percentage reported as activity, at one concentration (the size of the read-out at that concentration, not a potency): 12%
Compound 3: middle estimate off by 28 percentage points, on the high side, and the stated range covers the measured number.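

Replacing 2-(methylsulfanyl)phenyl with 3-methoxyphenyl on a double-bonded chain carbon bound to a double-bonded chain carbon gives a number 4 percentage points lower from compound 2 to compound 3 (within the scatter) in this assay, so the two compounds cannot be told apart on this read-out. Going by these compounds alone, this is the first measured step at this position, and it shows that the sulfur of the leaving group is not required for a strong effect at the one concentration tested, since a ring carrying oxygen instead serves as well. The data shown offer no explanation for this likeness.

Compound 1 differs from compound 2 in more than one place, so its record cannot be tied to any single change. From the compounds shown here alone, whether a far-end ring carrying an amine or a carboxylic acid would keep the strong effect remains open.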